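A few compounds are considered here, and "the series" means these few. Any claim that something is new, unique, unknown or untested is made for them only; others in the source may bear on it.

Compound 1 `Cc1ccccc1S(=O)(=O)Nc1ccc2oc(-c3ccccc3)nc2c1`: > 63000 nM in an assay on isolated protein for inhibition of malate dehydrogenase, mitochondrial (Sus scrofa), with stated times of 45 min and 30 min (on this read-out lower numbers stand for stronger inhibition and higher numbers for weaker inhibition), a limit of the assay.
Compound 2 `O=S(=O)(Nc1ccc(-c2nc3ccccc3o2)cc1)c1ccccc1C(F)(F)F`: > 63000 nM in this assay, a limit.
Compound 3 `COc1ccccc1S(=O)(=O)Nc1ccc(-c2nc3ccccc3o2)cc1`: > 63000 nM in this assay, a limit.

None of the three measured compounds gives a number: all sit at the limit of > 63000 nM in this assay, at which 3 of the 3 values shown sit. Compound 1 therefore stands at the limit and cannot be placed against the other two. Among the measured compounds shown here, the single measured step, a step that the two limits leave unreadable from compound 2 to compound 3, is unreadable for the same reason. The change to compound 4 `Cc1ccc(S(=O)(=O)Nc2ccc3oc(-c4ccccc4)nc3c2)cc1` is 4-methylphenyl in place of 2-methylphenyl on a sulfonyl sulfur. For the measured compounds named here, no measured step bears on this change, so no direction or size can be foreseen from the data; the expectation is simply that compound 4 also stays at the limit, with no step beyond the scatter. Compound 4 is expected to give 100000 nM, with a range from 30000 nM to 300000 nM. The expected step from compound 1 is a step that the limit leaves unreadable from compound 1 to compound 4.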

Compound 4, half-maximal inhibitory concentration: > 63000 nM
Compound 4 ended at the assay's limit; the forecaster's own chance of this, stated with the estimate: 85%; the middle value is on the limit's open side.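

Compound 1 and compound 4 both stand at a limit, so 4-methylphenyl in place of 2-methylphenyl gives no readable step: the limit of > 63000 nM in this assay, at which 4 of the 4 values shown sit. The compounds shown leave open which structural change, if any, would give a true number in this assay.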